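The compounds below may be only part of what the source reports. "The series", "measured", "known", "first", "only" and "open" are said of these compounds alone.

Among the measured compounds shown here, compound 1 `ClCc1ccc(Cn2cnc3c(Cl)ncnc32)cc1` is one of three compounds measured in a functional assay on IGROV-1 cells (Homo sapiens) for cytotoxicity, read by sulforhodamine B assay, with a stated time of 48 h; a higher number here means that more compound is tolerated, a lower number that less compound is tolerated. In this assay compound 1 gives only a limit, > 100000 nM, and no number. The other two carry the same kind of benzyl group in a different arrangement: compound 2 `ClCc1ccccc1Cn1cnc2c(Cl)nc(Cl)nc21` gives 7070 nM in this assay, and compound 3 `ClCc1ccccc1Cn1cnc2c(Cl)ncnc21` gives 55000 nM. For the measured compounds named here, the one measured step that bears on the question is a 7.8-fold higher number from compound 2 to compound 3 (0.89 log units; beyond the scatter). Compound 4 `ClCc1ccc(Cn2cnc3c(Cl)nc(Cl)nc32)cc1` differs from compound 1 by chloro in place of hydrogen on an aromatic carbon, which is the reverse of that step in direction. From the compounds shown here alone, because compound 1 sits at the limit of > 100000 nM in this assay, at which 1 of the 3 values shown sits, its true value is unknown, so the starting point of the step is itself uncertain. A step of roughly the size seen between compound 2 and compound 3 is expected, toward a lower number. The expected step is an at least 4.0-fold lower number from compound 1 to compound 4 (0.60 log units; beyond the scatter). For compound 4 the expected value in this assay is therefore 25000 nM, with a range from 6000 nM to 100000 nM.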

Compound 4, concentration lethal to 50% of the cells: 60300 nM
Beside the measured number, compound 4's estimate is 2.4-fold (0.38 log units) below it, and the stated range covers the measured number.
By their numbers in this assay, from the lowest: compound 2; then compounds 3 and 4 (each within the scatter of the next). At a limit, above all of these: compound 1.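

In this assay, the change to chloro on the aromatic carbon between two ring nitrogen atoms is now seen on a second arrangement of the benzyl group, as an at least 1.6-fold lower number from compound 1 to compound 4 (0.21 log units; that floor lies within the scatter). That figure is only a floor, so the new pair points the same way as the earlier step but does not by itself establish a step beyond the scatter. Whether the change has the same size on both cores cannot be read: the same change on two cores in this assay, a 7.8-fold higher number (0.89 log units; beyond the scatter) from compound 2 to compound 3 and an at least 1.6-fold higher number (0.21 log units; that floor lies within the scatter) from compound 4 to compound 1; the limit leaves it open whether they differ

The compounds shown leave open how an amine or a methoxy group on this same aromatic carbon would read in this assay. They also leave open the true value of compound 1, and with it the full size of this step: the limit of > 100000 nM in this assay, at which 1 of the 4 values shown sits.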